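From ureido to 2,5-dioxopyrrolidin-1-yl on the shared core

The source may report more compounds than this note shows. Statements on the series, on what has been measured and on what is new or still open speak of the compounds shown alone.

Compound 1 `N#CC1=C(N)N(c2ccc(S(N)(=O)=O)cc2)C2=C(C(=O)CCC2)C1c1ccc(Cl)cc1Cl` carries a free amine on the shared core, and in a functional assay on Ehrlich cells (Mus musculus) for cytotoxicity, read by trypan blue exclusion, with a stated time of 2 h (on this read-out higher numbers stand for weaker inhibition and lower numbers for stronger inhibition), compound 1 gives 25 ug/mL. Compound 3 `N#CC1=C(NC(N)=O)N(c2ccc(S(N)(=O)=O)cc2)C2=C(C(=O)CCC2)C1c1ccc(Cl)cc1Cl` has a carbamoyl on that amine nitrogen, and compound 3 gives 75 ug/mL, the higher of the two values that are true numbers. Compound 2 `CCCCNC(=S)NC1=C(C#N)C(c2ccc(Cl)cc2Cl)C2=C(CCCC2=O)N1c1ccc(S(N)(=O)=O)cc1` has a butylthiocarbamoyl group on the same nitrogen. Compound 2 reads > 100 ug/mL, which is a limit of the assay and not a number.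

Compound 4 `N#CC1=C(N2C(=O)CCC2=O)N(c2ccc(S(N)(=O)=O)cc2)C2=C(C(=O)CCC2)C1c1ccc(Cl)cc1Cl` differs from compound 3 as follows: 2,5-dioxopyrrolidin-1-yl in place of ureido on a double-bonded ring carbon. In short, 2,5-dioxopyrrolidin-1-yl stands in place of ureido on a double-bonded ring carbon. Among the measured compounds shown here, no measured compound carries this ring, so the evidence is indirect. Both measured substitutions on the amine nitrogen moved the number upward, with a 3.0-fold higher number from compound 1 to compound 3 (0.48 log units; beyond the scatter) and an at least 4.0-fold higher number from compound 1 to compound 2 (0.60 log units; beyond the scatter). Compound 4 also lacks the free amine, so its value is expected to lie nearer compound 3 than compound 1, with no clear direction from there. The estimated change in this assay is a 1.1-fold higher number from compound 3 to compound 4 (0.03 log units; within the scatter), which is expected to stay within the scatter. For compound 4 the estimated value is 80 ug/mL, with an expected range from 30 ug/mL to 200 ug/mL.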

Compound 4, half-maximal inhibitory concentration: 25 ug/mL
Estimate against measurement, compound 4: 3.2-fold (0.51 log units) above, and the stated range ends above it.
By their numbers in this assay, from the lowest: compounds 1 and 4 (each within the scatter of the next); then compound 3. At a limit, above all of these: compound 2.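

The earlier compounds shown here showed this position only with open-chain groups on the amine nitrogen, and both stood at higher numbers than the free amine. Compound 4 shows that a substituted nitrogen at this place need not raise the number in this assay: 2,5-dioxopyrrolidin-1-yl in place of amino gives no change at the digits printed from compound 1 to compound 4 (within the scatter). Set against the ureido group the ring gives a 3.0-fold lower number from compound 3 to compound 4 (0.48 log units; beyond the scatter), and set against the butylthiocarbamoyl-bearing group it gives an at least 4.0-fold lower number from compound 2 to compound 4 (0.60 log units; beyond the scatter), so the upward move seen with those two groups does not follow from substitution on this nitrogen alone. The reading of compound 2 is a limit of the assay and not a number: the limit of > 100 ug/mL in this assay, at which 1 of the 4 values shown sits.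

Among the compounds shown here, only one ring appears at this position, so the values cannot separate the part played by the ring from that of its two carbonyl groups or its size. On these data alone, a plain pyrrolidine ring, a six-membered piperidine-2,6-dione or a simple acetyl group on the amine nitrogen would each bear on that question, and what sets the ureido group apart from the ring remains open.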